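Fluoro in place of nitro: notes on compound 3

The source may hold more compounds than are shown below. What is called first, only, known or untested is meant among the compounds shown, and "the series" means these compounds.

Measured so far, in a functional assay on DU-145 cells (Homo sapiens) for inhibition, read by MTT assay, with a stated time of 24 h; a higher number here means a weaker inhibitor, a lower number a stronger inhibitor:
compound 1, `O=C(O)C1=Cc2ccccc2OC1(OCc1cc(-c2ccc([N+](=O)[O-])cc2)no1)C(F)(F)F` — 100000 nM
compound 2, `CCOC(=O)C1=Cc2ccccc2OC1(OCc1cc(-c2ccc([N+](=O)[O-])cc2)no1)C(F)(F)F` — > 150000 nM

Compound 1 is the free acid of the series. In this assay, among the measured compounds shown here, compound 1 gives 100000 nM, the only plain number in the set. Compound 2, the ethyl ester, stands at a limit of the assay, > 150000 nM, which is the limit of > 150000 nM in this assay, at which 1 of the 2 values shown sits. For the measured compounds named here, the one step that can be read, an at least 1.5-fold higher number from compound 1 to compound 2 (0.17 log units; that floor lies within the scatter), rests on that limit and therefore fixes no size of its own.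

Compound 3, `O=C(O)C1=Cc2ccccc2OC1(OCc1cc(-c2ccc(F)cc2)no1)C(F)(F)F`, keeps the free acid and the rest of the core of compound 1 and changes only the aryl substituent: fluoro in place of nitro on an aromatic carbon. Going by the values given here, no measured step concerns this position; the single measured step touches the ester end and carries nothing to the nitro-to-fluoro exchange. With no guide from the set, the step from compound 1 to compound 3 is expected to fall within the scatter, no change at the digits printed from compound 1 to compound 3 (within the scatter), with a real chance that only a limit is reported. Compound 3 is therefore estimated at 100000 nM, between 40000 nM and 250000 nM.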

Compound 3, half-maximal inhibitory concentration: 168000 nM
Beside the measured number, compound 3's estimate is 1.7-fold (0.23 log units) below it, and the stated range covers the measured number.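

In this assay, among the compounds shown here, the exchange of 4-nitrophenyl for 4-fluorophenyl on the free acid gives a 1.7-fold higher number from compound 1 to compound 3 (0.23 log units; within the scatter) and so provides the only reading at this position, since the earlier step concerned the ester end alone. Nitro, with 3 heavy atoms and 2 hydrogen-bond acceptors, and fluoro, with 1 heavy atom and 0 hydrogen-bond acceptors, therefore cannot be told apart here, and the nitro group is not needed to hold the reading of compound 1. Nothing at hand bears on why these two groups read alike at this place, on an aromatic carbon para to a large group.

On these data alone, a single exchange sets no rule for this position: whether an amine, a methoxy group or a plain hydrogen there would also stay within the scatter of compound 1 remains open. Also open, as far as these compounds go, is whether an amide in place of the free acid would separate from compound 1 at all, and how the fluoro group reads when it is carried on the ethyl ester.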